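This account rests on a few compounds, and the source may have more. Where it says the series, first, only, none or still open, it means among the compounds named here.

Compound 1 `N#CC1=C(N)Oc2c(c3nc4ccccc4nc3c3ccccc23)C12C(=O)N(Cc1cnnn1-c1ccccc1Cl)c1ccccc12` in an ADME assay on HUVEC cells (Homo sapiens) for antiproliferative activity, read by MTT assay, with a stated time of 48 h; on this read-out lower numbers stand for stronger inhibition and higher numbers for weaker inhibition: > 50000 nM, a limit of the assay and not a number.
Compound 2 `COc1ccc(-n2nncc2CN2C(=O)C3(C(C#N)=C(N)Oc4c3c3nc5ccccc5nc3c3ccccc43)c3ccccc32)cc1` in this assay: > 50000 nM, likewise a limit.
Compound 3 `N#CC1=C(N)Oc2c(c3nc4ccccc4nc3c3ccccc23)C12C(=O)N(Cc1cnnn1-c1ccc(S(N)(=O)=O)cc1)c1ccccc12` in this assay: > 50000 nM, likewise a limit.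

Compound 3 therefore stands only at a limit in this assay, and the other two values shown stand at the same limit (the limit of > 50000 nM in this assay, at which 3 of the 3 values shown sit). Compound 4 `N#CC1=C(N)Oc2c(c3nc4ccccc4nc3c3ccccc23)C12C(=O)N(Cc1cnnn1-c1cc(Cl)ccc1Cl)c1ccccc12` differs from compound 3 in one place: 2,5-dichlorophenyl in place of 4-sulfamoylphenyl on an aromatic nitrogen. Going by the values given here, two measured steps bear on this exchange of the group on the aromatic nitrogen. The step that the two limits leave unreadable from compound 1 to compound 3 and the step that the two limits leave unreadable from compound 2 to compound 3 both join two limits, so neither gives a readable size, and the third step that the two limits leave unreadable from compound 1 to compound 2 is unreadable for the same reason. Among the compounds with values here, nothing among the measured compounds shows that a change of the aryl group on the aromatic nitrogen moves the read-out off the limit in this assay. Compound 4 is therefore expected to sit at the same limit, with a step that the limit leaves unreadable from compound 3 to compound 4 expected to be no readable step. The estimate for compound 4 in this assay is 60000 nM, between 20000 nM and 200000 nM.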

Compound 4, half-maximal inhibitory concentration: > 50000 nM
Compound 4: only a limit was reported; the forecaster's own chance of this, stated with the estimate: 85%; the middle value lies beyond the limit too.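

In this assay compound 4 gives > 50000 nM, a limit of the assay and not a number, so the steps joining compound 4 to compound 1, compound 2 and compound 3 cannot be read. The compounds shown leave open whether any aryl group on the aromatic nitrogen can move the read-out off this limit: the limit of > 50000 nM in this assay, at which 4 of the 4 values shown sit.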